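A few compounds are considered here, and "the series" means these few. Any claim that something is new, unique, unknown or untested is made for them only; others in the source may bear on it.

Measured so far in an assay on CHO cells for displacement of a labelled ligand from prostaglandin D2 receptor 2 (Homo sapiens), read by scintillation counting; on this read-out lower numbers stand for stronger inhibition and higher numbers for weaker inhibition:
Compound 1 `CCS(=O)(=O)c1ccc(C)c(C#Cc2cc(Cl)ccc2OCC(=O)O)c1` gives 8.6 nM.
Compound 2 `COCCNS(=O)(=O)c1ccc(C)c(C#Cc2cc(Cl)ccc2OCC(=O)O)c1` gives 3.6 nM.
Compound 3 `CCCCCCc1ccncc1C#Cc1cc(Cl)ccc1OCC(=O)O` gives 43 nM.

Compound 2 has the lowest number of the three; compound 1 stands nearest to it and compound 3 furthest away. Compound 4 `Cc1ccc(S(=O)(=O)N2CCCCC2C)cc1C#Cc1cc(Cl)ccc1OCC(=O)O` has not been measured. It differs from compound 2 in one place: 2-methylpiperidin-1-yl in place of (2-methoxyethyl)amino on a sulfonyl sulfur. For the measured compounds named here, the only measured step at the same place, a 2.4-fold lower number from compound 1 to compound 2 (0.38 log units; beyond the scatter), shows that exchanging the group on the sulfonyl sulfur moved the number modestly. Compound 3 differs from compound 2 in more than one place, so its value shows only a higher number and bears little on this step. A modest step in either direction, or none beyond the scatter, is therefore expected in this assay. Compound 4 is expected to give 6 nM, between 2 nM and 20 nM, meaning a 1.7-fold higher number from compound 2 to compound 4 (0.22 log units; within the scatter).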

Compound 4, inhibition constant: 1.9 nM
The estimate for compound 4 lay 3.2-fold (0.50 log units) above the measured number; measured number below the stated range.
By their numbers in this assay, from the lowest: compounds 4 and 2 (each within the scatter of the next); then compound 1; then compound 3.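

In this assay, the ring of compound 4 brings a 1.9-fold lower number from compound 2 to compound 4 (0.28 log units; within the scatter), so this swap on the sulfonyl sulfur leaves the two compounds indistinguishable, even though the hydrogen-bond donor of (2-methoxyethyl)amino is gone. Set against the ethyl group, the same ring gives a 4.5-fold lower number from compound 1 to compound 4 (0.66 log units; beyond the scatter), so the position holds a six-membered ring with a methyl group and keeps a low number. Nothing available explains these numbers. As far as these compounds go, the part played by the ring's methyl group remains open. So does the reading for a plain piperidine, a morpholine or a dimethylamino group at this place.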